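Dienone series on prostate cells: biaryl variant of compound 1

The compounds below may be only part of what the source reports. "The series", "measured", "known", "first", "only" and "open" are said of these compounds alone.

Measured in a functional assay on LNCaP cells (Homo sapiens) for cytotoxicity, read by MTT assay, with a stated time of 72 h (on this read-out lower numbers stand for stronger inhibition and higher numbers for weaker inhibition), so far:
compound 1 `CC1=C(/C=C/C(=O)/C=C/c2ccc(C(F)(F)F)cc2)C(C)(C)CCC1`: 9100 nM
compound 2 `CC1=C(/C=C/C(=O)/C=C/c2ccccc2F)C(C)(C)CCC1`: 10700 nM
compound 3 `CC1=C(/C=C/C(=O)/C=C/c2cccc(C)c2)C(C)(C)CCC1`: 17800 nM

Compound 1 gives the lowest of the three numbers, but this says little: compound 2 and compound 3 both sit within the scatter of it, so the three aryl variants of the shared core are not separated by this assay. For the measured compounds named here, the only step between measured compounds that differ in one place is a 1.7-fold higher number from compound 2 to compound 3 (0.22 log units; within the scatter), a swap of one substituted phenyl for another, and it too stays within the scatter.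

Compound 4 `CC1=C(/C=C/C(=O)/C=C/c2ccc(-c3ccccc3)cc2)C(C)(C)CCC1` differs from compound 1 by phenyl in place of trifluoromethyl on an aromatic carbon. Going by the values given here, no measured pair swaps a small substituent for a whole aromatic ring, so nothing bears directly on this change; the closest guide is that the aryl swaps seen so far moved nothing beyond the scatter. The working expectation is therefore a step of a 1.0-fold lower number from compound 1 to compound 4 (0.00 log units; within the scatter), that is, no change beyond the scatter, with a wide range to cover the untested nature of the change. Compound 4 is estimated at 9000 nM in this assay, with a range from 3000 nM to 27000 nM.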

Compound 4, half-maximal inhibitory concentration: 14800 nM
The estimate for compound 4 lay 1.6-fold (0.22 log units) below the measured number; low and high end bracket the measured number.
By their numbers in this assay, from the lowest: compounds 1, 2, 4 and 3 (each within the scatter of the next).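

In this assay, the aromatic carbon para to a large group takes phenyl in place of trifluoromethyl with a 1.6-fold higher number from compound 1 to compound 4 (0.21 log units; within the scatter), so a whole aromatic ring here does not separate compound 4 from compound 1. For the compounds shown here, the earlier compounds compared only small groups on the aromatic ring, and their one step, a 1.7-fold higher number from compound 2 to compound 3 (0.22 log units; within the scatter), says nothing about a substituent that brings a ring of its own; the present step extends the flat picture to that larger kind of change, at this one position and for this one pair. No measurement at hand accounts for the result or assigns any effect to the phenyl or the trifluoromethyl group.

All four compounds shown keep the shared core and carry only carbon or fluorine substituents on the aromatic ring, so they leave open whether a group bearing nitrogen or oxygen, such as an amine or a carboxylic acid at this same position, would move the number beyond the scatter. Also open, from the compounds shown here alone, is whether a change to the core of compound 1 itself, rather than to its aromatic substituent, would separate any compound in this assay from the rest.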